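Acyl group variation in the polyamine amide series

A few compounds are considered here, and "the series" means these few. Any claim that something is new, unique, unknown or untested is made for them only; others in the source may bear on it.

For the measured compounds named here, compound 2 `NCCCNCCCCNCCCNC(=O)[C@H](CC1CCCCC1)NC(=O)C1CCCC1` gives 5.43 nM in an assay on cells for antagonist activity at Neuronal acetylcholine receptor; alpha4/beta2 (Homo sapiens), read by two-electrode voltage clamp, with a stated time of 1 min (on this read-out higher numbers stand for weaker inhibition and lower numbers for stronger inhibition), the lowest of the three numbers so far. Compound 1 `NCCCNCCCCNCCCNC(=O)[C@H](CC1CCCCC1)NC(=O)C1CCC1` gives 20.8 nM and compound 3 `NCCCNCCCCNCCCNC(=O)[C@H](CC1CCCCC1)NC(=O)CC1CC2CCC1C2` gives 25.6 nM. Compound 4 `NCCCNCCCCNCCCNC(=O)[C@H](CC1CCCCC1)NC(=O)c1ccccc1` carries phenyl in place of cyclopentyl on a carbonyl carbon. Going by the values given here, two measured steps bear on this: a 3.8-fold lower number from compound 1 to compound 2 (0.58 log units; beyond the scatter) shows a smaller ring on the carbonyl carbon giving a higher number, and a 4.7-fold higher number from compound 2 to compound 3 (0.67 log units; beyond the scatter) shows a larger saturated group doing the same. Phenyl is close to cyclopentyl in size, but no aromatic group has been measured in this series, so the direction is uncertain. A modest move to a higher number is expected, a 1.8-fold higher number from compound 2 to compound 4 (0.27 log units; within the scatter). Compound 4 is therefore estimated at 10 nM, with a range from 3 nM to 40 nM.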

Compound 4, half-maximal inhibitory concentration: 21.4 nM
The estimate for compound 4 lay 2.1-fold (0.33 log units) below the measured number; the measured number falls inside the stated range.
By their numbers in this assay, from the lowest: compound 2; then compounds 1, 4 and 3 (each within the scatter of the next).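

Phenyl on the carbonyl carbon gives a 3.9-fold higher number from compound 2 to compound 4 (0.60 log units; beyond the scatter) and so does not match cyclopentyl at this position. For the compounds shown here, the steps of a 1.0-fold higher number from compound 1 to compound 4 (0.01 log units; within the scatter) and a 1.2-fold lower number from compound 3 to compound 4 (0.08 log units; within the scatter) place compound 4 level with compound 1 and compound 3, which leaves cyclopentyl as the only one of the four groups set apart from the rest. Nothing available accounts for the gap between cyclopentyl and phenyl. Still open, going by these compounds, is whether cyclohexyl or a pyridine ring on this carbonyl carbon would stand with compound 2 or with the other three.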